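From Isopropyl to Cyclobutyl: Expected Liver Microsome Stability

A few compounds are considered here, and "the series" means these few. Any claim that something is new, unique, unknown or untested is made for them only; others in the source may bear on it.

Compound 1, `CCOc1cc([C@](O)(CCN(C)C)[C@@H](c2cc3cc(Br)ccc3nc2OC)c2ccnc(OC)c2OC)cc(OC)n1`, gives 7.6 uL/min in an ADME assay on microsomes from liver (Mus musculus) for metabolic stability; a higher number here means faster removal of the compound, a lower number slower removal.
Compound 2, `COc1cc([C@](O)(CCN(C)C)[C@@H](c2cc3cc(Br)ccc3nc2OC)c2cccc(OC)c2F)cc(OC(C)C)n1`, gives 6 uL/min in this assay.
Compound 3, `COc1cc([C@](O)(CCN(C)C)[C@@H](c2cc3cc(Br)ccc3nc2OC)c2ccnc(OC)c2OC)cc(OC(C)C)n1`, gives 6.7 uL/min in this assay.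

Compound 3 holds the second highest of the three numbers, yet the gaps to its neighbours are small: a 1.1-fold higher number from compound 2 to compound 3 (0.05 log units; within the scatter) and a 1.1-fold lower number from compound 1 to compound 3 (0.05 log units; within the scatter), both within the scatter, so the three compounds cannot be told apart in this assay.

Compound 4, `COc1cc([C@](O)(CCN(C)C)[C@@H](c2cc3cc(Br)ccc3nc2OC)c2ccnc(OC)c2OC)cc(OC2CCC2)n1`, differs from compound 3 by cyclobutyl in place of isopropyl on an oxygen on an aromatic ring. The measured step that bears most on this change is the one at the same oxygen on an aromatic ring, methyl in place of hydrogen on a saturated chain carbon, which gave a 1.1-fold lower number from compound 1 to compound 3 (0.05 log units; within the scatter). The other step, 2,3-dimethoxypyridin-4-yl in place of 2-fluoro-3-methoxyphenyl, also stayed within the scatter, a 1.1-fold higher number from compound 2 to compound 3 (0.05 log units; within the scatter). Growing the alkyl group on that oxygen has so far left this assay unchanged, so no step beyond the scatter is expected, with a 1.1-fold higher number from compound 3 to compound 4 (0.05 log units; within the scatter) as the estimated change. Compound 4 is therefore expected to give 7.5 uL/min in this assay, with a range from 4 uL/min to 14 uL/min.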

Compound 4, intrinsic clearance in a liver preparation (reported as CLH), per the amount of preparation that the assay uses: 4.6 uL/min
Estimate against measurement, compound 4: 1.6-fold (0.21 log units) above; the measured number falls inside the stated range.
By their numbers in this assay, from the lowest: compounds 4, 2, 3 and 1 (each within the scatter of the next).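

Cyclobutyl brings a ring to the oxygen on an aromatic ring, where the earlier compounds carried only open chains, and this assay still shows no step beyond the scatter: replacing isopropyl gives a 1.5-fold lower number from compound 3 to compound 4 (0.16 log units; within the scatter) and replacing ethyl gives a 1.7-fold lower number from compound 1 to compound 4 (0.22 log units; within the scatter). Ethyl, isopropyl and cyclobutyl at this oxygen therefore cannot be told apart here, so the earlier reading now extends from open chains to this four-membered ring. No measurement at hand bears on why these groups read alike.

The compounds shown leave open whether a larger ring such as cyclohexyl, or a chain carrying an amine, would move the number beyond the scatter at this oxygen. They also leave open whether cyclobutyl reads the same with 2-fluoro-3-methoxyphenyl in place of 2,3-dimethoxypyridin-4-yl.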